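From tert-butoxy to phenyl on a carbonyl carbon

The source may report more compounds than this note shows. Statements on the series, on what has been measured and on what is new or still open speak of the compounds shown alone.

In a functional assay on RPMI-8226 cells (Homo sapiens) for cytotoxicity, read by MTT assay, with a stated time of 48 h (a lower number here means a stronger inhibitor, a higher number a weaker inhibitor), compound 1 `C#CCOC(=O)NN=C1C(Cl)=C(Cl)C(Cl)=C1Cl` gives 800 nM, while compound 2 `CC(C)(C)OC(=O)NN=C1C(Cl)=C(Cl)C(Cl)=C1Cl` gives 100 nM, the lower of the two numbers. Among the compounds with values here, the only measured step, an 8.0-fold lower number from compound 1 to compound 2 (0.90 log units; beyond the scatter), comes from tert-butyl in place of propargyl, and it lies beyond the usual scatter. So a change in this part of the molecule has already moved the number clearly. Compound 3 `O=C(NN=C1C(Cl)=C(Cl)C(Cl)=C1Cl)c1ccccc1` differs from compound 2 in a different way: phenyl in place of tert-butoxy on a carbonyl carbon. In short, it has phenyl in place of tert-butoxy on a carbonyl carbon. Within the data shown here, no measured step covers this exact swap, so the earlier step serves only as a rough guide to size. A higher number in this assay seems the likelier direction, and the expected move is a 2.5-fold higher number from compound 2 to compound 3 (0.40 log units; beyond the scatter). For compound 3 the estimated value is 250 nM, with an expected range from 60 nM to 1000 nM.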

Compound 3, half-maximal inhibitory concentration: 600 nM
Estimate against measurement, compound 3: 2.4-fold (0.38 log units) below, and the stated range covers the measured number.
By their numbers in this assay, from the lowest: compound 2; then compounds 3 and 1 (each within the scatter of the next).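

In this assay, the change to phenyl in place of tert-butoxy on a carbonyl carbon gives a 6.0-fold higher number from compound 2 to compound 3 (0.78 log units; beyond the scatter), so the low number seen with tert-butoxy is not kept when this group is replaced by an aromatic ring. Phenyl in place of propargyloxy gives a 1.3-fold lower number from compound 1 to compound 3 (0.12 log units; within the scatter), which leaves these two groups indistinguishable here, while the tert-butoxy compound stands apart from both with steps beyond the scatter. Nothing available here accounts for this difference.

The compounds shown leave open how an isopropoxy group, a cyclohexyl ring or an amine on this carbonyl carbon would compare with tert-butoxy. They also leave open whether a methoxy group or a chlorine on the phenyl ring would shift the number for compound 3.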